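The compounds below may be only part of what the source reports. "The series", "measured", "known", "first", "only" and "open" are said of these compounds alone.

Measured so far in an assay on isolated protein for inhibition of Aromatase (Homo sapiens), read by fluorescence and colorimetric assay, with a stated time of 30 min; a lower number here means a stronger inhibitor, a higher number a weaker inhibitor:
- compound 1, `CCCCCCCCCCc1cn(C(c2ccc(C#N)cc2)c2ccc(C#N)cc2)nn1`: 16000 nM
- compound 2, `N#Cc1ccc(OCc2cn(C(c3ccc(C#N)cc3)c3ccc(C#N)cc3)nn2)cc1`: 4640 nM
- compound 3, `CCCc1cn(C(c2ccccc2)c2ccccc2)nn1`: 11000 nM

Compound 3 sits second highest of the three numbers in this assay. Its nearest neighbour is compound 1, which lies within the scatter of it, so the two cannot be ordered; compound 2 lies clearly lower, beyond the scatter.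

The next compound, compound 4, `c1ccc(OCc2cn(C(c3ccccc3)c3ccccc3)nn2)cc1`, is not yet measured. It differs from compound 3 in one place: phenoxy in place of ethyl on a saturated chain carbon bound to an aromatic carbon.

Among the measured compounds shown here, one measured step bears on this change. Between compound 1 and compound 2 a 4-cyanophenoxy group takes the place of nonyl at the same kind of position, and this assay moved a 3.4-fold lower number from compound 1 to compound 2 (0.54 log units; beyond the scatter). That step swaps an alkyl chain for an aryl ether, as here, though the group that enters there carries a nitrile, and the pair of compound 1 and compound 2 carries nitrile groups on the core that compound 3 and compound 4 lack. The step from compound 3 to compound 4 is therefore expected to run in the same direction, toward a lower number. A somewhat smaller step is expected here, a 1.8-fold lower number from compound 3 to compound 4 (0.26 log units; within the scatter).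

Compound 4 is accordingly estimated at 6000 nM in this assay, with a range from 2500 nM to 15000 nM.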

Compound 4, half-maximal inhibitory concentration: 31300 nM
Beside the measured number, compound 4's estimate is 5.2-fold (0.72 log units) below it; the whole stated range lies below it.
By their numbers in this assay, from the lowest: compound 2; then compounds 3, 1 and 4 (each within the scatter of the next, the first and the last beyond it).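

In this assay, phenoxy in place of ethyl on a saturated chain carbon bound to an aromatic carbon gives a 2.8-fold higher number from compound 3 to compound 4 (0.45 log units; beyond the scatter), whereas 4-cyanophenoxy in place of nonyl at the same kind of place gives a 3.4-fold lower number from compound 1 to compound 2 (0.54 log units; beyond the scatter). Both steps lie beyond the scatter and run in opposite directions, so exchanging an alkyl chain for an aryl ether at this place has no single direction across these two pairs, which differ in the chain that leaves, in the nitrile on the entering group and in the nitrile groups on the core. No measurement at hand accounts for this reversal.

The compounds shown do not separate the contributions of the nitrile on the entering group, the nitrile groups on the core and the length of the chain that leaves, so which of these goes with the change in direction remains open. Also open, on these data alone, is how the number responds at this place to a group of another kind, such as an amine or a carboxylic acid.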